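Aryl sulfonyl variation: what to expect for compound 4

The compounds below may be only part of what the source reports. "The series", "measured", "known", "first", "only" and "open" are said of these compounds alone.

Measured so far:
compound 1, `O=S(=O)(NCCCNc1nccc(-c2c(-c3cccc(F)c3)nc3sccn23)n1)c1cccc(F)c1`: 8550 nM
compound 2, `O=S(=O)(NCCCNc1nccc(-c2c(-c3cccc(F)c3)nc3sccn23)n1)c1ccc(Br)cc1`: 9400 nM
compound 3, `O=S(=O)(NCCCNc1nccc(-c2c(-c3cccc(F)c3)nc3sccn23)n1)c1ccc(C(F)(F)F)cc1`: 11700 nM

In a functional assay on SK-MEL-28 cells (Homo sapiens) for cytotoxicity, read by MTT assay (a higher number here means a weaker inhibitor, a lower number a stronger inhibitor), compound 1 gives 8550 nM and compound 2 gives 9400 nM. Compound 3 gives 11700 nM, the highest of the three numbers, yet the steps to it are small: a 1.4-fold higher number from compound 1 to compound 3 (0.14 log units; within the scatter) and a 1.2-fold higher number from compound 2 to compound 3 (0.10 log units; within the scatter). The remaining step, a 1.1-fold higher number from compound 1 to compound 2 (0.04 log units; within the scatter), is also within the scatter. Among the measured compounds shown here, on these three numbers no compound can be ranked against another; the aryl group on the sulfonyl sulfur has so far left this assay unmoved.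

Compound 4 is `O=S(=O)(NCCCNc1nccc(-c2c(-c3cccc(F)c3)nc3sccn23)n1)c1ccc(Cl)cc1`. The change from compound 3 is chloro in place of trifluoromethyl on an aromatic carbon. The step that bears most directly on it is a 1.2-fold higher number from compound 2 to compound 3 (0.10 log units; within the scatter), an exchange at the same aromatic carbon that stayed within the scatter; the steps of a 1.1-fold higher number from compound 1 to compound 2 (0.04 log units; within the scatter) and a 1.4-fold higher number from compound 1 to compound 3 (0.14 log units; within the scatter) add the same message from the other two aryl groups. No shown step beyond the scatter exists in this set, so for compound 4 no step beyond the scatter is expected in this assay: a 1.2-fold lower number from compound 3 to compound 4 (0.09 log units; within the scatter). Compound 4 is therefore estimated at 9500 nM, with a range from 5000 nM to 19000 nM.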

Compound 4, half-maximal inhibitory concentration: 8450 nM
For compound 4 the middle estimate is 1.1-fold (0.05 log units) above the measured one; the measured number falls inside the stated range.
By their numbers in this assay, from the lowest: compounds 4, 1, 2 and 3 (each within the scatter of the next).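

In this assay, chloro in place of trifluoromethyl on this aromatic carbon, para to a large group, gives a 1.4-fold lower number from compound 3 to compound 4 (0.14 log units; within the scatter), so going from four heavy atoms to a single chlorine atom at this position leaves the result within the scatter. The exchange of one halogen for another at the same carbon gives a 1.1-fold lower number from compound 2 to compound 4 (0.05 log units; within the scatter), and 4-chlorophenyl in place of 3-fluorophenyl on the sulfonyl sulfur gives a 1.0-fold lower number from compound 1 to compound 4 (0.01 log units; within the scatter); both steps also stay within the scatter, so the four aryl groups now shown cannot be ranked against one another. No other measurement bears on this result.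

The para substituents shown are limited to bromo, trifluoromethyl and chloro, so it remains open whether an amine or a carboxylic acid on this aromatic carbon, or a longer chain there, would produce a step beyond the scatter. Also open is whether replacing the aryl group on the sulfonyl sulfur with a simple methyl group would move the number at all, since every compound shown keeps an aromatic ring at that place.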